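A Fluorinated Aryl Swap in a Growth-Inhibition Series

This account rests on a few compounds, and the source may have more. Where it says the series, first, only, none or still open, it means among the compounds named here.

In a functional assay on A549 cells (Homo sapiens) for inhibition, read by CCK-8 assay, with a stated time of 72 h, tested at 10 uM (on this read-out lower numbers stand for less inhibition of growth and higher numbers for more inhibition of growth at the one concentration tested), three compounds share one core and differ only in the aryl group on an amide-type nitrogen. Compound 1 `Cc1cccc(NC(=O)C2(C(=O)Nc3ccc(Nc4ncc5cc(C(=O)N(C)C)n(C6CCCC6)c5n4)cc3)CC2)c1` gives 86.1%, compound 2 `COC(=O)c1ccc(NC(=O)C2(C(=O)Nc3ccc(Nc4ncc5cc(C(=O)N(C)C)n(C6CCCC6)c5n4)cc3)CC2)cc1` gives 92% and compound 3 `CN(C)C(=O)c1cc2cnc(Nc3ccc(NC(=O)C4(C(=O)Nc5ccc(Cl)cc5)CC4)cc3)nc2n1C1CCCC1` gives 101%. Compound 2 cannot be separated from the other two on these numbers: the data show a number 5.9 percentage points higher from compound 1 to compound 2 (within the scatter), and also a number 9 percentage points higher from compound 2 to compound 3 (within the scatter). For the measured compounds named here, only one measured step leaves the scatter, and it stays modest: a number 14.9 percentage points higher from compound 1 to compound 3 (beyond the scatter).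

Compound 4 `CN(C)C(=O)c1cc2cnc(Nc3ccc(NC(=O)C4(C(=O)Nc5ccccc5F)CC4)cc3)nc2n1C1CCCC1` has 2-fluorophenyl in place of 4-(methoxycarbonyl)phenyl on an amide-type nitrogen. Going by the values given here, no measured compound carries 2-fluorophenyl, so the estimate rests on the three steps at this same nitrogen, which are all small. No step beyond the scatter is therefore expected, and the estimated step is a number 1 percentage points lower from compound 2 to compound 4 (within the scatter). For compound 4 the expected value is 91%, within an estimated range of 78% to 103%.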

Compound 4, percent growth inhibition at one concentration: 88.6%
Compound 4: middle estimate off by 2.4 percentage points, on the high side; measured number inside the range.
By their numbers in this assay, from the lowest: compounds 1, 4, 2 and 3 (each within the scatter of the next, the first and the last beyond it).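

With 2-fluorophenyl on the amide-type nitrogen, this assay gives a number 2.5 percentage points higher from compound 1 to compound 4 (within the scatter) and a number 3.4 percentage points lower from compound 2 to compound 4 (within the scatter) so a fluorine-bearing aryl group, smaller than 4-(methoxycarbonyl)phenyl by the heavy-atom counts, falls within the scatter of both of these compounds. The change from 4-chlorophenyl gives a number 12.4 percentage points lower from compound 3 to compound 4 (beyond the scatter) and this modest step is the second to leave the scatter, so compound 3 now stands apart from two of the three other compounds, though not from compound 2. Nothing measured here accounts for these steps.

The step to compound 4 changes both the halogen and its place on the ring, so the compounds shown leave open which of the two matters. They also leave open how a plain phenyl group, or an aryl group carrying an amine or a carboxylic acid, would read at this nitrogen.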